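N-Alkyl Amides as Bile Acid Receptor Agonists

This account rests on a few compounds, and the source may have more. Where it says the series, first, only, none or still open, it means among the compounds named here.

Measured compounds:
compound 1, `CC(C)(C)c1onc(-c2c(Cl)cccc2Cl)c1COc1ccc(/C=C/c2cccc(C(=O)O)c2)c(Cl)c1`, 1300 nM
compound 2, `CC(C)c1onc(-c2c(Cl)cccc2Cl)c1COc1ccc(C(=O)Nc2cccc(C(=O)O)c2)c(Cl)c1`, 3000 nM
compound 3, `CC(C)c1onc(-c2c(Cl)cccc2Cl)c1COc1ccc(C(=O)N(C)c2cccc(C(=O)O)c2)c(Cl)c1`, 3100 nM

In a functional assay on HEK293 cells for agonist activity at Bile acid receptor (Homo sapiens) (a lower number here means that less compound is needed, a higher number that more compound is needed for the effect), compound 3 gives the highest number of the three; compound 2 lies within the scatter of it, while compound 1 gives a number beyond the scatter lower. Compound 4, `CCCN(C(=O)c1ccc(OCc2c(-c3c(Cl)cccc3Cl)noc2C(C)C)cc1Cl)c1cccc(C(=O)O)c1`, differs from compound 3 by ethyl in place of hydrogen on a saturated chain carbon bound to an amide-type nitrogen. Among the measured compounds shown here, the only measured step on the amide nitrogen, a 1.0-fold higher number from compound 2 to compound 3 (0.01 log units; within the scatter), bears on this change and was flat. Lengthening the same substituent further is therefore expected to leave this assay largely unchanged, with a step of a 1.0-fold lower number from compound 3 to compound 4 (0.01 log units; within the scatter). Compound 4 is estimated at 3000 nM, between 1200 nM and 7500 nM.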

Compound 4, half-maximal effective concentration: 2100 nM
Compound 4: the middle estimate sits 1.4-fold (0.15 log units) above what was measured; low and high end bracket the measured number.
By their numbers in this assay, from the lowest: compounds 1, 4, 2 and 3 (each within the scatter of the next, the first and the last beyond it).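

On an amide-type nitrogen, propyl proves no different from the smaller substituents in this assay: methyl to propyl gives a 1.5-fold lower number from compound 3 to compound 4 (0.17 log units; within the scatter), and propyl in place of hydrogen gives a 1.4-fold lower number from compound 2 to compound 4 (0.15 log units; within the scatter), so this position stays flat across hydrogen, methyl and propyl. Nothing shown explains this flatness. On these data alone, whether a longer chain, a branched isopropyl group, or a chain ending in an amine or a carboxylic acid on this nitrogen would shift the number remains open.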